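Methoxyphenyl in Place of Dichlorophenyl on the Carbonyl Carbon

The source may report more compounds than this note shows. Statements on the series, on what has been measured and on what is new or still open speak of the compounds shown alone.

Of the compounds shown here, three sharing one core have been measured in a functional assay on OVCAR-4 cells (Homo sapiens) for cytotoxicity, read by sulforhodamine B assay, with a stated time of 48 h, tested at 0.01 uM; on this read-out lower numbers stand for a stronger effect and higher numbers for a weaker effect at the one concentration tested. Compound 1 `COc1cc(-c2cc(/C=C/C(=O)c3ccc(N)cc3)[nH]n2)cc(OC)c1OC` gives 85%, compound 2 `COc1cc(-c2cc(/C=C/C(=O)c3ccc(Cl)c(Cl)c3)[nH]n2)cc(OC)c1OC` gives 92%, and compound 3 `COc1ccc(-c2cc(/C=C/C(=O)c3cc(OC)c(OC)c(OC)c3)[nH]n2)cc1OC` gives 94%. Compound 2 holds the second highest of the three numbers; compound 3 is nearest to it and compound 1 furthest, and both gaps lie within the scatter. Among the measured compounds shown here, the only single-point step among them, a number 7 percentage points higher from compound 1 to compound 2 (within the scatter), is also within the scatter.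

Compound 4 `COc1ccc(C(=O)/C=C/c2cc(-c3cc(OC)c(OC)c(OC)c3)n[nH]2)cc1` is not yet measured. It differs from compound 2 by 4-methoxyphenyl in place of 3,4-dichlorophenyl on a carbonyl carbon. For the measured compounds named here, the one step that bears on this change sits on the same carbonyl carbon, a number 7 percentage points higher from compound 1 to compound 2 (within the scatter), and produced no movement beyond the scatter. Nothing in these three compounds therefore suggests that a change of the group on this carbon shifts the read-out.

Compound 4 is accordingly expected to stay close to compound 2, with an expected step of a number 1 percentage points lower from compound 2 to compound 4 (within the scatter), giving an estimate of 91% within a range from 80% to 100%.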

Compound 4, a percentage reported as activity, at one concentration (the size of the read-out at that concentration, not a potency): 91%
Compound 4: the middle estimate sits on the measured number at the digits printed; the measured number falls inside the stated range.
By their numbers in this assay, from the lowest: compounds 1, 4, 2 and 3 (each within the scatter of the next).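

In this assay, the group on the carbonyl carbon has now been varied across compounds 1, 2 and 4 without the read-out leaving the scatter: the step is a number 1 percentage points lower from compound 2 to compound 4 (within the scatter), and the exchange of methoxy for amino on an aromatic carbon gives a number 6 percentage points higher from compound 1 to compound 4 (within the scatter). Replacing 3,4-dichlorophenyl with 4-methoxyphenyl removes both chlorine atoms and introduces a hydrogen-bond acceptor at the same heavy-atom count, yet this too yields no step beyond the scatter. No further data bear on why these changes leave the number in place.

The compounds shown leave open whether a carboxylic acid or a piperidine on this carbonyl carbon would produce a step beyond the scatter. They also leave open whether replacing the phenyl ring there with a longer chain would do so.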